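Furan-2-yl to pyridin-2-yl on the shared core

This account rests on a few compounds, and the source may have more. Where it says the series, first, only, none or still open, it means among the compounds named here.

Three measured compounds share one core and differ in the group on the aromatic carbon of the outer ring and in the five- or six-membered aromatic ring on the other side. Compound 1 `Fc1cccc(Nc2nccc(-c3ccccn3)n2)c1` gives 1000 nM in a functional assay for inhibition, with Homo sapiens as the target; a higher number here means a weaker inhibitor, a lower number a stronger inhibitor. For the measured compounds named here, compound 2 `CC(=O)Nc1cccc(Nc2nccc(-c3ccccn3)n2)c1` gives 300 nM; the only measured step, a 3.3-fold lower number from compound 1 to compound 2 (0.52 log units; beyond the scatter), is acetamido in place of fluoro on an aromatic carbon. Compound 3 `CCc1cccc(Nc2nccc(-c3ccco3)n2)c1` gives 9700 nM, the highest of the three numbers, beyond the scatter from compound 1 and from compound 2.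

Compound 4 `CCc1cccc(Nc2nccc(-c3ccccn3)n2)c1` differs from compound 3 by pyridin-2-yl in place of furan-2-yl on an aromatic carbon. Going by the values given here, the step from compound 1 to compound 2 concerns a different position and does not bear on this exchange; no measured pair isolates the furan-2-yl to pyridin-2-yl change. What compounds 1 and 2 show is that both compounds carrying pyridin-2-yl give far lower numbers than compound 3. Compound 4 carries the same pyridin-2-yl and differs from compound 1 only by ethyl where compound 1 has fluoro. Compound 4 is therefore expected at about 1000 nM, within an estimated range of 300 nM to 3000 nM. The expected step of a 9.7-fold lower number from compound 3 to compound 4 (0.99 log units; beyond the scatter) is a large decrease, because compound 1 gives 1000 nM.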

Compound 4, half-maximal inhibitory concentration: 1400 nM
For compound 4 the middle estimate is 1.4-fold (0.15 log units) below the measured one, within the range that was stated.
By their numbers in this assay, from the lowest: compound 2; then compounds 1 and 4 (each within the scatter of the next); then compound 3.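

Notes on the series: in this assay, the exchange of furan-2-yl for pyridin-2-yl now has a matched pair with ethyl held constant, and the change gives a 6.9-fold lower number from compound 3 to compound 4 (0.84 log units; beyond the scatter). For the compounds shown here, the lower number seen with pyridin-2-yl is therefore tied to this place on the six-membered aromatic ring with 2 nitrogen, and no longer rests on compounds that also differ in the other group. With pyridin-2-yl fixed, the other varied place gives a 1.4-fold higher number from compound 1 to compound 4 (0.15 log units; within the scatter), so ethyl and fluoro are not separated there, whereas a 4.7-fold higher number from compound 2 to compound 4 (0.67 log units; beyond the scatter) leaves acetamido apart from ethyl. No supporting data are available to explain any of these steps.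

From the compounds shown here alone, whether the furan-2-yl to pyridin-2-yl exchange has a similar size with fluoro or acetamido in place of ethyl remains open, since the matched pair covers ethyl alone. Also open, going by these compounds, are how a phenyl ring or pyridin-3-yl would compare with pyridin-2-yl at this place, and whether a longer chain, an amine or a carboxylic acid in place of ethyl would keep the number near that of compound 4.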